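The source may hold more compounds than are shown below. What is called first, only, known or untested is meant among the compounds shown, and "the series" means these compounds.

Measured so far in a functional assay on COLO 205 cells (Homo sapiens) for antiproliferative activity, read by MTT assay, with a stated time of 68 h; on this read-out lower numbers stand for stronger inhibition and higher numbers for weaker inhibition: compound 1 `O=S(=O)(Nc1ccc(F)c(C#Cc2cnc3[nH]ncc3c2)c1F)c1ccccc1` gives 2100 nM; compound 2 `O=S(=O)(Nc1ccc(F)c(C#Cc2cnc3[nH]ncc3c2)c1F)c1cccc(F)c1` gives 758 nM; compound 3 `CCOc1n[nH]c2ncc(C#Cc3c(F)ccc(NS(=O)(=O)c4cccnc4)c3F)cc12` gives 1980 nM.

Compound 3 stands second highest of the three numbers. Its nearest neighbour is compound 1, within the scatter, while compound 2 sits further off, lower and beyond the scatter. For the measured compounds named here, the only single-point step measured, a 2.8-fold lower number from compound 1 to compound 2 (0.44 log units; beyond the scatter), concerns the sulfonyl aryl and not the fused core.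

Compound 4 `O=S(=O)(Nc1ccc(F)c(C#Cc2cnc3[nH]nc(-c4cccc(Cl)c4)c3c2)c1F)c1cccnc1` differs from compound 3 by 3-chlorophenyl in place of ethoxy on an aromatic carbon. Going by the values given here, no measured step touches this position on the fused core; the one available step, a 2.8-fold lower number from compound 1 to compound 2 (0.44 log units; beyond the scatter), sits elsewhere and is modest. There is thus no basis in the measured compounds for predicting a direction, and the working expectation for this assay is no step beyond the scatter, with a wide band around it. Compound 4 is accordingly expected near 1500 nM, with a range from 300 nM to 7000 nM. The step this estimate implies is a 1.3-fold lower number from compound 3 to compound 4 (0.12 log units; within the scatter).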

Compound 4, half-maximal inhibitory concentration: > 10000 nM
Compound 4 was reported as a limit; the forecaster's own chance of this, stated with the estimate: 5%; middle value at least 6.6-fold (0.82 log units) away from the limit.
By their numbers in this assay, from the lowest: compound 2; then compounds 3 and 1 (each within the scatter of the next). At a limit, above all of these: compound 4.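

For the compounds shown here, this is the only measured change at this aromatic carbon of the five-membered ring, and it shows that the position is not indifferent to what it carries: in this assay, 3-chlorophenyl in place of ethoxy gives an at least 5.0-fold higher number from compound 3 to compound 4 (0.70 log units; beyond the scatter). Going by these compounds alone, the earlier compounds could not show this, as their one step lay on the sulfonyl aryl and left this carbon untouched. The value of compound 4 is a limit and not a number, so the step gives only a lower bound on the change: the limit of > 10000 nM in this assay, at which 1 of the 4 values shown sits.

Nothing shown separates the contribution of the phenyl ring from that of the chlorine, and the ethoxy group has no neighbours in size or kind at this carbon. On these data alone, whether an unsubstituted phenyl, a methoxy group, a longer alkoxy chain or an amine here would stay near compound 3 remains open.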